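From Difluorophenyl to Methoxyphenyl: an Expected Flat Step

The compounds below may be only part of what the source reports. "The series", "measured", "known", "first", "only" and "open" are said of these compounds alone.

Compound 1 `CC(C)Cc1csc(N)c1C(=O)c1ccc(Cl)cc1` gives 1% in an assay on CHO cells for displacement of a labelled ligand from adenosine receptor A1 (Homo sapiens), read by scintillation counting, tested at 10 uM; a higher number here means more inhibition at the concentration tested (going by the name of the read-out), a lower number less inhibition.
Compound 2 `Cc1c(-c2ccccc2)sc(N)c1C(=O)c1ccc(Cl)cc1` gives 1% in this assay.
Compound 3 `CC(C)(C)Cc1c(-c2c(F)cccc2F)sc(N)c1C(=O)c1ccc(Cl)cc1` gives 1% in this assay.

In this assay compound 3 stands level with compounds 1 and 2 at the digits reported; its gaps to compound 1 and to compound 2 both lie within the usual scatter, so no order can be read among the three. Compound 4 `COc1ccc(-c2sc(N)c(C(=O)c3ccc(Cl)cc3)c2CC(C)(C)C)cc1` differs from compound 3 in one place: 4-methoxyphenyl in place of 2,6-difluorophenyl on an aromatic carbon. Among the compounds with values here, no measured pair shows what such a change does here. With all three measured compounds sitting at the bottom of the read-out, no step beyond the scatter is expected in either direction. Compound 4 is estimated at 2%, with a range from 0% to 12%. That corresponds to an expected step of a number 1 percentage points higher from compound 3 to compound 4 (within the scatter).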

Compound 4, a percentage reported as inhibition, at one concentration (the size of the read-out at that concentration, not a potency): 1%
Compound 4: the middle estimate sits 1 percentage points above what was measured; low and high end bracket the measured number.
By their numbers in this assay, from the lowest: compounds 1, 2, 3 and 4 (each within the scatter of the next).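

Within the data shown here, with 4-methoxyphenyl in place of 2,6-difluorophenyl on the aromatic carbon next to the ring sulfur, this assay shows no change at the digits printed from compound 3 to compound 4 (within the scatter) as the first step that can be read between compounds differing in one place. The entering group carries a hydrogen-bond acceptor and the leaving group none, yet this swap leaves the read-out at the bottom of its range. Nothing measured here explains this flat result. On these data alone, whether an amine or a carboxylic acid on this carbon would raise the inhibition stays open, as does the effect of a longer chain in place of the neopentyl group.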